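The source may report more compounds than this note shows. Statements on the series, on what has been measured and on what is new or still open speak of the compounds shown alone.

Measured so far:
compound 1 `CC(C)(C)OC(=O)NCC1CCCN(C(=O)CN2CN(c3ccccc3)C3(CCN(C(=O)c4ccc(C(C)(C)C)cc4)CC3)C2=O)C1` — 9500 nM
compound 2 `CCC1CCCN(C(=O)CN2CN(c3ccccc3)C3(CCN(C(=O)c4ccc(C(C)(C)C)cc4)CC3)C2=O)C1` — 3900 nM

In an assay on HEK293 cells for displacement of a labelled ligand from NPC1-like intracellular cholesterol transporter 1 (Homo sapiens) (on this read-out lower numbers stand for stronger inhibition and higher numbers for weaker inhibition), compound 2 gives 3900 nM, the lower of the two numbers; compound 1 gives 9500 nM. Within the data shown here, the one measured step, a 2.4-fold lower number from compound 1 to compound 2 (0.39 log units; beyond the scatter), came with methyl in place of (tert-butoxycarbonyl)amino on a saturated chain carbon bound to a saturated ring carbon. Compound 3 `CCOC(=O)C1CCCN(C(=O)CN2CN(c3ccccc3)C3(CCN(C(=O)c4ccc(C(C)(C)C)cc4)CC3)C2=O)C1` differs from compound 2 by ethoxycarbonyl in place of ethyl on a saturated ring carbon. That step, on a ring carbon rather than a chain carbon, is only loosely comparable to the measured one, so the expected change a 1.4-fold higher number from compound 2 to compound 3 (0.15 log units; within the scatter) is small, possibly none beyond the scatter. Compound 3 is therefore estimated at 5500 nM, within 2200 nM to 14000 nM.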

Compound 3, half-maximal inhibitory concentration: 8200 nM
Beside the measured number, compound 3's estimate is 1.5-fold (0.17 log units) below it; the measured number falls inside the stated range.
By their numbers in this assay, from the lowest: compound 2; then compounds 3 and 1 (each within the scatter of the next).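

Ethoxycarbonyl on this saturated ring carbon, two ring bonds from the ring nitrogen, goes with a 2.1-fold higher number from compound 2 to compound 3 (0.32 log units; beyond the scatter) and so shows that exchanging the group on the ring itself can move the number beyond the scatter. Ethoxycarbonyl and ((tert-butoxycarbonyl)amino)methyl show a 1.2-fold lower number from compound 1 to compound 3 (0.06 log units; within the scatter) and cannot be told apart here, leaving ethyl alone with the lowest number. Nothing available explains this difference. Going by these compounds, what remains open is how a carboxylic acid, an amine or a longer alkyl chain on this carbon would read, and whether any group here gives a lower number than ethyl.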